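The source may hold more compounds than are shown below. What is called first, only, known or untested is meant among the compounds shown, and "the series" means these compounds.

Measured in a functional assay on T98G cells (Homo sapiens) for inhibition, read by colorimetric assay and MTT assay, with a stated time of 72 h; a lower number here means a stronger inhibitor, a higher number a weaker inhibitor:
- Compound 1 `C=CCCCCOc1ccccc1-c1cnc(OCCCC=C)n1C`: 3000 nM
- Compound 2 `C=CCCCCOc1ccccc1-c1cnc(OCCCCC=C)n1C`: 4000 nM
- Compound 3 `C=CCCCCOc1ccccc1-c1cnc(OC)n1C`: > 100000 nM

Compound 3 has only a limit and no number, and it stands at the limit of > 100000 nM in this assay, at which 1 of the 3 values shown sits.

Compound 4 `C=CCCCCOc1ccccc1-c1cnc(OCCOCC=C)n1C` shares the core of compound 3 and differs from it as follows: (allyloxy)methyl in place of hydrogen on a saturated chain carbon bound to an oxygen on an aromatic ring. The group enters on the same saturated chain carbon where compound 1 and compound 2 carry but-3-en-1-yl and pent-4-en-1-yl. Removing those chains gave large steps: an at least 33-fold higher number from compound 1 to compound 3 (1.52 log units; beyond the scatter), and an at least 25-fold higher number from compound 2 to compound 3 (1.39 log units; beyond the scatter). Changing the chain itself gave a 1.3-fold higher number from compound 1 to compound 2 (0.12 log units; within the scatter), which lies within the scatter. Unlike those chains, (allyloxy)methyl contains an oxygen, and no measured compound shows what that does. A large step to a lower number is therefore expected, reversing the two losses, though with some added uncertainty. The expected change is an at least 16-fold lower number from compound 3 to compound 4 (1.22 log units; beyond the scatter). In this assay the estimate for compound 4 is 6000 nM, with an expected range of 2000 nM to 20000 nM.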

Compound 4, half-maximal inhibitory concentration: 65000 nM
Estimate against measurement, compound 4: 11-fold (1.03 log units) below; measured number above the stated range.
By their numbers in this assay, from the lowest: compounds 1 and 2 (each within the scatter of the next); then compound 4. At a limit, above all of these: compound 3.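

In this assay, an oxygen within the chain matters at this position: allyloxy in place of allyl, on a saturated chain carbon two bonds along the chain from an oxygen on an aromatic ring, gives a 22-fold higher number from compound 1 to compound 4 (1.34 log units; beyond the scatter), and allyloxy in place of but-3-en-1-yl gives a 16-fold higher number from compound 2 to compound 4 (1.21 log units; beyond the scatter). The all-carbon chains of compound 1 and compound 2 had shown only that such a chain could be changed without a step beyond the scatter, whereas compound 4 shows that the atoms within the chain also count. Compound 3 carries only a limit: the limit of > 100000 nM in this assay, at which 1 of the 4 values shown sits. Placing (allyloxy)methyl in place of hydrogen on a saturated chain carbon bound to an oxygen on an aromatic ring gives an at least 1.5-fold lower number from compound 3 to compound 4 (0.18 log units; that floor lies within the scatter).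

From the compounds shown here alone, whether the loss follows from the oxygen itself or from where it stands in the chain remains open. So does how a longer chain, an amine or a carboxylic acid would fare at this position.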